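The compounds below may be only part of what the source reports. "The series", "measured", "known", "first", "only" and "open" are said of these compounds alone.

Series notes. Compound 1 `O=C1/C(=C/c2cccc(F)c2)CN(S(=O)(=O)c2ccc(Br)cc2)C/C1=C\c1cccc(F)c1` and compound 2 `N#Cc1ccc(S(=O)(=O)N2C/C(=C\c3cccc(F)c3)C(=O)/C(=C/c3cccc(F)c3)C2)cc1` share one core; compound 3 `O=C1/C(=C/c2ccc(F)cc2)CN(S(=O)(=O)c2ccc(Br)cc2)C/C1=C\c1ccc(F)cc1` and compound 4 `N#Cc1ccc(S(=O)(=O)N2C/C(=C\c3ccc(F)cc3)C(=O)/C(=C/c3ccc(F)cc3)C2)cc1` share another. The difference between the two cores is not broken down here. In an ADME assay on L02 cells (Homo sapiens) for cytotoxicity, read by MTT assay, with a stated time of 24 h (a higher number here means a weaker inhibitor, a lower number a stronger inhibitor), compound 1 gives 15800 nM, compound 2 gives 15500 nM and compound 3 gives 16400 nM; all three numbers lie within the usual scatter of one another, so no ordering among them is claimed.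

One change, cyano in place of bromo on an aromatic carbon, occurs twice in this set. In the measured pair it is cyano in place of bromo on an aromatic carbon, and it gave a 1.0-fold lower number from compound 1 to compound 2 (0.01 log units; within the scatter). The same change, (cyano in place of bromo on an aromatic carbon), separates compound 3 from compound 4; the surroundings of the place read the same in both cases, so it is taken as the same change, not merely the same kind.

Compound 4 has not yet been measured in this assay. Because the earlier step was a 1.0-fold lower number from compound 1 to compound 2 (0.01 log units; within the scatter), the step from compound 3 to compound 4 is expected to be of similar size, a 1.0-fold lower number from compound 3 to compound 4 (0.01 log units; within the scatter). Compound 4 is therefore estimated at 16000 nM in this assay, with an expected range from 9000 nM to 28000 nM.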

Compound 4, half-maximal inhibitory concentration: 14700 nM
The estimate for compound 4 lay 1.1-fold (0.04 log units) above the measured number, and the stated range covers the measured number.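

In this assay, cyano in place of bromo on an aromatic carbon gives a 1.1-fold lower number from compound 3 to compound 4 (0.05 log units; within the scatter), and the step set beside the earlier one shows no difference between the two cores: the same change on two cores in this assay, a 1.0-fold lower number (0.01 log units; within the scatter) from compound 1 to compound 2 and a 1.1-fold lower number (0.05 log units; within the scatter) from compound 3 to compound 4, 1.1-fold (0.04 log units) apart, within the scatter of two such steps

Within these four compounds, then, the change from 4-bromophenyl to 4-cyanophenyl reads the same on both cores, and on neither does it move the number beyond the scatter. This does not show that bromo and cyano are interchangeable on other cores or in other assays, and since both steps lie within the scatter, the agreement is between two steps too small to read, not the carrying over of a sizeable effect.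

Still open, from the compounds shown here alone, is whether another group at the place held by bromo and cyano, such as an amine, a carboxylic acid or a methoxy group, would give a step beyond the scatter. Also open, going by these compounds, is whether the change would read the same on a core carrying chloro or hydroxy in place of the fluoro groups.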